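From Compound 3 to Compound 4: One Ring Grows

This account rests on a few compounds, and the source may have more. Where it says the series, first, only, none or still open, it means among the compounds named here.

compound 1 `CCCCCCN(C)CNCC(=O)[C@H](CC(=O)O)NC(=O)C(CC)n1ccnc(NCc2nonc2C)c1=O`: 0.13 nM
compound 2 `CCC(C(=O)N[C@@H](CC(=O)O)C(=O)CNCN1CCCC1)n1ccnc(NCc2nonc2C)c1=O`: 0.84 nM
compound 3 `CCC(C(=O)N[C@@H](CC(=O)O)C(=O)CNCN1Cc2ccccc2C1)n1ccnc(NCc2nonc2C)c1=O`: 1.52 nM

All three compounds were tested in a functional assay on NT2 cells (Homo sapiens) for inhibition; on this read-out higher numbers stand for weaker inhibition and lower numbers for stronger inhibition. Compound 3 stands with compound 2 at the upper end of these numbers, since the series shows a 1.8-fold higher number from compound 2 to compound 3 (0.26 log units; within the scatter), and that step does not separate them. Compound 1 is set clearly apart, with a 12-fold higher number from compound 1 to compound 3 (1.07 log units; beyond the scatter).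

The next analogue, compound 4 `CCC(C(=O)N[C@@H](CC(=O)O)C(=O)CNCN1CCc2ccccc2C1)n1ccnc(NCc2nonc2C)c1=O`, keeps the shared core and alters one group only: a group of 10 heavy atoms (9 carbon, 1 nitrogen; one six-membered non-aromatic ring with 1 hetero atom, one six-membered aromatic ring of carbon only) in place of a group of 9 heavy atoms (8 carbon, 1 nitrogen; one five-membered non-aromatic ring with 1 hetero atom, one six-membered aromatic ring of carbon only), on a saturated chain carbon bound to an amine nitrogen.

Within the data shown here, three measured steps touch this place. The large 12-fold higher number from compound 1 to compound 3 (1.07 log units; beyond the scatter) and the modest 6.5-fold higher number from compound 1 to compound 2 (0.81 log units; beyond the scatter) both leave the open-chain hexyl(methyl)amino group of compound 1 for a ring, so they say little about exchanging one ring group for another. Among the measured compounds shown here, the closest precedent is a 1.8-fold higher number from compound 2 to compound 3 (0.26 log units; within the scatter), a ring-for-ring exchange that added more heavy atoms than this one and still stayed within the scatter. Resting on compound 3 at 1.52 nM, no step beyond the scatter is expected in this assay, in either direction. The expected change is a 1.1-fold higher number from compound 3 to compound 4 (0.02 log units; within the scatter). The estimated value for compound 4 is 1.6 nM, with an expected range of 0.5 nM to 5 nM.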

Compound 4, half-maximal inhibitory concentration: 1.25 nM
Beside the measured number, compound 4's estimate is 1.3-fold (0.11 log units) above it; the measured number falls inside the stated range.
By their numbers in this assay, from the lowest: compound 1; then compounds 2, 4 and 3 (each within the scatter of the next).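

In this assay, enlarging the five-membered non-aromatic ring to a six-membered one on the fused group gives a 1.2-fold lower number from compound 3 to compound 4 (0.08 log units; within the scatter) and so adds a second ring-for-ring exchange that stays within the scatter, while 1,2,3,4-tetrahydroisoquinolin-2-yl in place of pyrrolidin-1-yl gives a 1.5-fold higher number from compound 2 to compound 4 (0.17 log units; within the scatter) and likewise does not separate the two compounds. With 1,2,3,4-tetrahydroisoquinolin-2-yl in place of hexyl(methyl)amino, the step is a 9.6-fold higher number from compound 1 to compound 4 (0.98 log units; beyond the scatter), so all three ring groups shown at this place, on a saturated chain carbon bound to an amine nitrogen, now stand clearly apart from the open-chain group, and ring size and the fused aromatic ring make no readable difference among them. Nothing available explains these numbers, neither the gap to the open chain nor the flatness among the rings.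

The compounds shown leave open how much of the gap depends on the length of the open chain, for instance whether butyl(methyl)amino or octyl(methyl)amino would sit with hexyl(methyl)amino or with the ring groups. They also leave open whether a ring group bearing a long alkyl chain, such as 4-hexylpiperidin-1-yl, would behave like the open chain or like the rings.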